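A few compounds are considered here, and "the series" means these few. Any claim that something is new, unique, unknown or untested is made for them only; others in the source may bear on it.

In a functional assay on BMEC cells (Bos taurus) for antiproliferative activity (on this read-out higher numbers stand for weaker inhibition and lower numbers for stronger inhibition), compound 2 `COc1cc(/C=C/Cc2cc(O)c3ccoc3c2)cc(OC)c1OC` gives 27700 nM, the highest of the two exact numbers, and compound 1 `COc1cc(/C=C\Cc2cc(O)c3ccoc3c2)cc(OC)c1OC` gives 49 nM. The step is large, a 570-fold higher number from compound 1 to compound 2 (2.75 log units; beyond the scatter), and the fact that compounds 1 and 2 differ only in the configuration as drawn stands behind it. Compound 3 `COc1cc(/C=C\Cc2cc(O)c3c(-c4ccccc4)csc3c2)cc(OC)c1OC` gives only a limit, > 2000 nM. Compound 4 `COc1cc(/C=C/Cc2cc(O)c3cc(-c4ccccc4)oc3c2)cc(OC)c1OC` departs from compound 2 by phenyl in place of hydrogen on an aromatic carbon. Within the data shown here, no measured step covers this change, since the one step known concerns configuration alone. Compound 3, which carries a phenyl group, offers no sign of a gain with its > 2000 nM. The expected change is therefore none beyond the scatter, a 1.3-fold higher number from compound 2 to compound 4 (0.10 log units; within the scatter). The estimate for compound 4 is 35000 nM, with an expected range of 10000 nM to 100000 nM.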

Compound 4, half-maximal inhibitory concentration: > 20000 nM
Compound 4 ended at the assay's limit; the forecaster's own chance of this, stated with the estimate: 40%; the middle value lies beyond the limit too.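

Compound 4 gives > 20000 nM in this assay and this is a limit, so the step from compound 2 to compound 4 cannot be read. The compounds shown leave open whether phenyl in place of hydrogen on an aromatic carbon changes the number at all.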